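Replacing dimethylamino on the carbonyl carbon of compound 2

The source may report more compounds than this note shows. Statements on the series, on what has been measured and on what is new or still open speak of the compounds shown alone.

Values so far in a physicochemical assay for lipophilicity, using the shake flask method, measured as octanol-water partition; on this read-out higher numbers stand for higher lipophilicity and lower numbers for lower lipophilicity
compound 1 `CCOc1cc(C2=NN(c3ccc(C#N)c(C)c3)[C@@H](C3CCCC3)C2)ccc1C(=O)O` gives 2.7
compound 2 `COc1nc(C2=NN(c3ccc(C#N)c(C)c3)[C@@H](C3CCCC3)C2)ccc1C(=O)N(C)C` gives 3.5
compound 3 `COc1nc(C2=NN(c3ccc(C#N)c(C)n3)[C@@H](C3CCCC3)C2)ccc1C(=O)N(C)C` gives 4.1

Compound 2 stands in the middle of these three numbers, with compound 3 above it and compound 1 below it, both gaps beyond the scatter. The change to compound 4 `COc1nc(C2=NN(c3ccc(C#N)c(C)c3)[C@@H](C3CCCC3)C2)ccc1C(=O)Nc1nnn[nH]1`, not yet measured, is (1H-tetrazol-5-yl)amino in place of dimethylamino on a carbonyl carbon. Going by the values given here, the one measured step of a number 0.60 log units higher from compound 2 to compound 3 (beyond the scatter) lies at another place, on an amine nitrogen in a ring, so it gives only a scale and no direction. Among the compounds with values here, no measured step touches the carbonyl carbon. Compound 1, whose carbonyl carbon carries no dimethylamino, gives 2.7 but differs elsewhere too, so it is only a loose guide. A fall larger than the measured step is expected, beyond the scatter, and this expectation is uncertain. The expected step is a number 1.30 log units lower from compound 2 to compound 4 (beyond the scatter). In this assay compound 4 is estimated at 2.2 within an expected range of 1.4 to 3 for now.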

Compound 4, distribution coefficient: 3.2
For compound 4 the middle estimate is 1.00 log units below the measured one; measured number outside the range, above it.
By their numbers in this assay, from the lowest: compound 1; then compounds 4 and 2 (each within the scatter of the next); then compound 3.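

In this assay, (1H-tetrazol-5-yl)amino in place of dimethylamino on a carbonyl carbon gives a number 0.30 log units lower from compound 2 to compound 4 (within the scatter), the only step shown at this position. The read-out therefore does not separate the two groups, although the entering group brings one five-membered aromatic ring with 4 hetero atoms, 2 hydrogen-bond donors and 3 hydrogen-bond acceptors, and the leaving group has none of these. No measurement at hand accounts for this outcome.

From the compounds shown here alone, it remains open how other groups on this carbonyl carbon, such as methylamino or morpholine, would read in this assay. Going by these compounds, it is also open whether the same exchange would give a comparable step with the 5-cyano-6-methylpyridin-2-yl group of compound 3 in place.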